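The source may report more compounds than this note shows. Statements on the series, on what has been measured and on what is new or still open speak of the compounds shown alone.

Of the compounds shown here, three sharing one core have been tested for growth inhibition. Compound 1 `COc1ccccc1/C=N/c1c(C)n(C)n(-c2ccccc2)c1=O` gives 70800000 nM in a functional assay on HT-29 cells (Homo sapiens) for cytotoxicity, read by MTT assay, with a stated time of 72 h; on this read-out higher numbers stand for weaker inhibition and lower numbers for stronger inhibition. Compound 2 `Cc1c(/N=C/c2ccc(Cl)cc2Cl)c(=O)n(-c2ccccc2)n1C` gives 178000000 nM, and compound 3 `Cc1c(/N=C/c2ccc(O)cc2)c(=O)n(-c2ccccc2)n1C` gives 389000000 nM, the highest of the three numbers; both a 5.5-fold higher number from compound 1 to compound 3 (0.74 log units; beyond the scatter) and a 2.2-fold higher number from compound 2 to compound 3 (0.34 log units; beyond the scatter) lie beyond the scatter. Compound 4 `Cc1c(/N=C/c2cccc(Cl)c2)c(=O)n(-c2ccccc2)n1C` differs from compound 3 in one place: 3-chlorophenyl in place of 4-hydroxyphenyl on a carbon with a double bond to nitrogen. The nearest guide is the step of a 2.2-fold higher number from compound 2 to compound 3 (0.34 log units; beyond the scatter), in which a chlorine-bearing ring gave a lower number than the 4-hydroxyphenyl ring. A modest lowering is therefore expected for compound 4, with a 2.2-fold lower number from compound 3 to compound 4 (0.33 log units; beyond the scatter). The estimate for compound 4 is 180000000 nM, within a range from 90000000 nM to 400000000 nM.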

Compound 4, half-maximal inhibitory concentration: 269000000 nM
Compound 4: the middle estimate sits 1.5-fold (0.17 log units) below what was measured, within the range that was stated.
By their numbers in this assay, from the lowest: compound 1; then compounds 2, 4 and 3 (each within the scatter of the next, the first and the last beyond it).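

In this assay, replacing 4-hydroxyphenyl with 3-chlorophenyl, which has no hydrogen-bond donor or acceptor, gives a 1.4-fold lower number from compound 3 to compound 4 (0.16 log units; within the scatter), so the two compounds cannot be told apart. The 3-chlorophenyl and 2,4-dichlorophenyl groups also cannot be told apart, with a 1.5-fold higher number from compound 2 to compound 4 (0.18 log units; within the scatter), whereas the 2-methoxyphenyl group of compound 1 stands apart, with a 3.8-fold higher number from compound 1 to compound 4 (0.58 log units; beyond the scatter). Nothing available explains these results. Going by these compounds, it remains open whether a phenyl ring carrying an amine or a carboxylic acid at this place would change the number.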